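Changing the carboxy side chain on an amide-type nitrogen

A few compounds are considered here, and "the series" means these few. Any claim that something is new, unique, unknown or untested is made for them only; others in the source may bear on it.

Of the compounds shown here, three with the same core have been tested so far in a functional assay on PC-3 cells (Homo sapiens) for antiproliferative activity, read by MTT assay, with a stated time of 24 h (on this read-out higher numbers stand for weaker inhibition and lower numbers for stronger inhibition), across this small series. Compound 1 (`CCn1c(C(=O)NCCO)ccc1C(CC)(CC)c1ccc(OCS(=O)(=O)c2ccccc2)c(C)c1`) gives 17700 nM there. Compound 2 (`CCn1c(C(=O)N[C@@H](CO)C(C)C)ccc1C(CC)(CC)c1ccc(OCS(=O)(=O)c2ccccc2)c(C)c1`) gives 10600 nM there. Compound 3 (`CCn1c(C(=O)N[C@H](C(=O)O)C(C)C)ccc1C(CC)(CC)c1ccc(OCS(=O)(=O)c2ccccc2)c(C)c1`) gives 3650 nM and holds the lowest number of the three, with both gaps beyond the scatter.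

Compound 4 (`CCn1c(C(=O)NCCC(=O)O)ccc1C(CC)(CC)c1ccc(OCS(=O)(=O)c2ccccc2)c(C)c1`) differs from compound 3 in one place: 2-carboxyethyl in place of 1-carboxy-2-methylpropyl on an amide-type nitrogen.

For the measured compounds named here, no measured step makes this exact change, so the evidence is indirect. Compound 4 keeps a carboxy group, and the two steps that introduced one were a 4.8-fold lower number from compound 1 to compound 3 (0.69 log units; beyond the scatter) and a 2.9-fold lower number from compound 2 to compound 3 (0.46 log units; beyond the scatter) in size. Those steps suggest no large loss. The closest guide to dropping the isopropyl part is the step with isopropyl in place of hydrogen, which was a 1.7-fold lower number from compound 1 to compound 2 (0.22 log units; within the scatter) and so small. Run in reverse, it points only weakly towards a higher number.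

In this assay the expected change is a 1.6-fold higher number from compound 3 to compound 4 (0.22 log units; within the scatter) and thus a small one. Compound 4 is estimated at 6000 nM within an expected range of 2500 nM to 14000 nM overall.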

Compound 4, half-maximal inhibitory concentration: 14400 nM
For compound 4 the middle estimate is 2.4-fold (0.38 log units) below the measured one; the whole stated range lies below it.
By their numbers in this assay, from the lowest: compound 3; then compounds 2, 4 and 1 (each within the scatter of the next).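

In this assay a carboxy group alone does not bring the low number seen for compound 3: with carboxy in place of hydroxy on the unbranched chain, the step is a 1.2-fold lower number from compound 1 to compound 4 (0.09 log units; within the scatter) and stays within the scatter. The step that lies beyond the scatter is the change of 1-carboxy-2-methylpropyl to 2-carboxyethyl, which gives a 3.9-fold higher number from compound 3 to compound 4 (0.60 log units; beyond the scatter) and leaves compound 3 apart from the other three compounds, while the comparison with the branched hydroxy side chain gives a 1.4-fold higher number from compound 2 to compound 4 (0.13 log units; within the scatter) and also stays within the scatter. No measurement shown here gives a reason for this pattern.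

The change from compound 3 to compound 4 removes the isopropyl part and also alters the chain between the amide-type nitrogen and the carboxy group, so the compounds shown cannot separate these two effects. A 1-carboxyethyl or carboxymethyl group on the same nitrogen would help to tell them apart, and the mirror-image form of 1-carboxy-2-methylpropyl, or an amine in place of its carboxy group, remains an open comparison.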